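Fluoro on the phenyl of compound 1: expected effect

The source may hold more compounds than are shown below. What is called first, only, known or untested is meant among the compounds shown, and "the series" means these compounds.

Of the compounds shown here, two carry numbers so far. Compound 1 `Nc1ccccc1NC(=O)c1ccc(CSC(=S)N2CCN(c3ccccc3)CC2)cc1` is the higher of the two: in a functional assay on HeLa cells (Homo sapiens) for antiproliferative activity, read by CCK-8 assay, with a stated time of 72 h, tested at 2 uM (on this read-out higher numbers stand for a stronger effect at the one concentration tested and lower numbers for a weaker effect), compound 1 gives 62.2%. Compound 2 `Nc1ccccc1NC(=O)c1ccc(CSC(=S)N2CCc3cc(Cl)ccc32)cc1` gives 40.1% in this assay, a gap beyond the usual scatter. Compound 3 `Nc1ccccc1NC(=O)c1ccc(CSC(=S)N2CCN(c3ccccc3F)CC2)cc1` is not yet measured; it differs from compound 1 by fluoro in place of hydrogen on an aromatic carbon, read one bond further out as phenyl to 2-fluorophenyl. Among the compounds with values here, no measured step of this kind exists, so only a small change is expected, the step of a number 2.2 percentage points lower from compound 1 to compound 3 (within the scatter) staying within the scatter. Compound 3 is thus estimated at 60% in this assay, with a range from 45% to 75%.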

Compound 3, a percentage reported as inhibition, at one concentration (the size of the read-out at that concentration, not a potency): 17.5%
The estimate for compound 3 lay 42.5 percentage points above the measured number, and the stated range ends above it.
By their numbers in this assay, from the lowest: compound 3; then compound 2; then compound 1.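

In this assay, fluoro in place of hydrogen on an aromatic carbon, ortho to a large group, gives a number 44.7 percentage points lower from compound 1 to compound 3 (beyond the scatter). Within the data shown here, this is the first single-place step, and it shows that the phenyl of compound 1 does not tolerate every change: even one added fluorine atom at this place can matter greatly.

On these data alone, whether chloro or methoxy on the same carbon, or fluoro on another carbon of that phenyl, would give a step of similar size remains open. Nothing at hand accounts for the size of this step.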